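The source may report more compounds than this note shows. Statements on the series, on what has been measured and on what is new or still open speak of the compounds shown alone.

Compound 1 `O=C(Nc1ccc(-n2ncc3c(Br)cccc32)cc1)Nc1ccc(Cl)c(C(F)(F)F)c1` carries a 4-bromo-1H-indazol-1-yl group on one aryl arm of the shared core. Within the data shown here, in a functional assay on MDA-MB-231 cells (Homo sapiens) for cytotoxicity, read by MTT assay, with a stated time of 72 h (on this read-out higher numbers stand for weaker inhibition and lower numbers for stronger inhibition), compound 1 gives 7700 nM, the highest of the two numbers measured so far. Among the measured compounds shown here, the only other measured compound, compound 2 `O=C(Nc1ccc(-n2ncc3c(Cl)cccc32)cc1)Nc1ccc(C(F)(F)F)cc1`, gives 2700 nM in this assay, a lower number, and the gap between the two lies beyond the usual scatter. For the measured compounds named here, compound 2 differs from compound 1 in two places at once, so no single step between measured compounds can be isolated from these two numbers.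

Compound 3 `O=C(Nc1ccc(-n2ncc3ccncc32)cc1)Nc1ccc(Cl)c(C(F)(F)F)c1` has not yet been measured. It differs from compound 1 as follows: a group of 9 heavy atoms (6 carbon, 3 nitrogen; one five-membered aromatic ring with 2 hetero atoms, one six-membered aromatic ring with 1 hetero atom) in place of a group of 10 heavy atoms (7 carbon, 2 nitrogen, 1 bromine; one five-membered aromatic ring with 2 hetero atoms, one six-membered aromatic ring of carbon only), on an aromatic carbon. The change sits on an aromatic carbon of a six-membered aromatic ring of carbon only, para to a large group. Going by the values given here, no measured step matches this change, so its direction cannot be read from the data; the expectation is a step not beyond the scatter, with a slight lean toward a higher number. The expected step from compound 1 to compound 3 in this assay is a 1.2-fold higher number from compound 1 to compound 3 (0.07 log units; within the scatter). Compound 3 is estimated to give 9000 nM in this assay, within a range from 3000 nM to 27000 nM.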

Compound 3, half-maximal inhibitory concentration: > 32000 nM
Compound 3: no number, only a limit; the forecaster's own chance of this, stated with the estimate: 10%; at least 3.5-fold (0.55 log units) between middle value and limit.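

Compound 3 gives no exact number in this assay: its > 32000 nM is a limit of the assay. Among these compounds, compound 2 had differed from compound 1 in two places at once, so this is the first comparison that changes only one place, the group on an aromatic carbon of the six-membered aromatic ring of carbon only, para to a large group, and swapping 4-bromo-1H-indazol-1-yl for the nitrogen-richer group gives an at least 4.1-fold higher number from compound 1 to compound 3 (0.61 log units; beyond the scatter), which means weaker inhibition in this read-out and shows that the outcome depends on the group at this position. The step gives only a minimum, and its full size stays unknown: the limit of > 32000 nM in this assay, at which 1 of the 3 values shown sits.

This single swap removes the bromine and also places a hetero atom in the six-membered aromatic ring, so the compounds shown cannot tell which of these two differences accounts for the step. As far as these compounds go, an unsubstituted 1H-indazol-1-yl group, which has neither the bromine nor that extra ring nitrogen, could help separate the two, and how a 4-chloro-1H-indazol-1-yl group or an amine would behave on this same carbon, with the rest of compound 1 kept, remains open.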